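A few compounds are considered here, and "the series" means these few. Any claim that something is new, unique, unknown or untested is made for them only; others in the source may bear on it.

Series notes, values from an ADME assay on the whole organism (Rattus norvegicus, strain Sprague-Dawley) for protein binding, read by LC-MS, with a stated time of 30 min, at a dose of 1 mg/kg by the intravenous route; on this read-out higher numbers stand for fast clearance and lower numbers for slow clearance:
- compound 1 `N#Cc1ccc(S(=O)(=O)[C@H]2CN(S(=O)(=O)c3ccc(C#N)cc3Cl)C[C@@]2(O)CO)cc1`: 4 mL/min/kg
- compound 2 `N#Cc1ccc(S(=O)(=O)N2C[C@H](S(=O)(=O)c3ccc(Cl)cc3)[C@](O)(CO)C2)c(Cl)c1`: 12 mL/min/kg
- compound 3 `N#Cc1ccc(S(=O)(=O)N2C[C@H](S(=O)(=O)c3ccc(Cl)cn3)[C@](O)(CO)C2)c(Cl)c1`: 11 mL/min/kg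

Compound 3 sits at the upper end of these three numbers, within the scatter of compound 2. Compound 4 `N#Cc1ccc(S(=O)(=O)N2C[C@H](S(=N)(=O)c3ccc(Cl)cc3)[C@](O)(CO)C2)c(Cl)c1` differs from compound 3 by a group of 10 heavy atoms (6 carbon, 1 nitrogen, 1 oxygen, 1 sulfur, 1 chlorine; one six-membered aromatic ring of carbon only) in place of a group of 10 heavy atoms (5 carbon, 1 nitrogen, 2 oxygen, 1 sulfur, 1 chlorine; one six-membered aromatic ring with 1 hetero atom), on a saturated ring carbon, on a saturated ring carbon. The closest measured precedent is a 1.1-fold lower number from compound 2 to compound 3 (0.04 log units; within the scatter), an exchange of aromatic rings on a sulfonyl sulfur. Larger but still modest are a 3.0-fold higher number from compound 1 to compound 2 (0.48 log units; beyond the scatter) and a 2.8-fold higher number from compound 1 to compound 3 (0.44 log units; beyond the scatter). Within the data shown here, no measured step tests the entering group directly, so no step beyond the scatter is expected in this assay. The expected step is a 1.1-fold lower number from compound 3 to compound 4 (0.04 log units; within the scatter), in no firm direction. Compound 4 is estimated at 10 mL/min/kg, with an expected range of 5 mL/min/kg to 20 mL/min/kg.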

Compound 4, clearance: 4.8 mL/min/kg
For compound 4 the middle estimate is 2.1-fold (0.32 log units) above the measured one; measured number below the stated range.
By their numbers in this assay, from the lowest: compounds 1 and 4 (each within the scatter of the next); then compounds 3 and 2 (each within the scatter of the next).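

In this assay a change on this saturated ring carbon moves the number beyond the scatter, giving a 2.5-fold lower number from compound 2 to compound 4 (0.40 log units; beyond the scatter) and also a 2.3-fold lower number from compound 3 to compound 4 (0.36 log units; beyond the scatter) while the earlier exchange of aromatic rings on the sulfonyl sulfur stayed within it. With the 4-chlorophenyl ring kept from compound 2, the step to compound 4 changes only the sulfur group, an imino nitrogen replacing one sulfonyl oxygen, so this position responds to a change at sulfur. No available evidence accounts for this shift. Still open, from the compounds shown here alone, is how a methyl group on that imino nitrogen would read, and whether the 5-chloropyridin-2-yl ring on the same imino sulfur would match compound 4.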